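A few compounds are considered here, and "the series" means these few. Any claim that something is new, unique, unknown or untested is made for them only; others in the source may bear on it.

Measured compounds in a functional assay on SW480 cells (Homo sapiens) for cytotoxicity, read by MTT assay, with a stated time of 48 h; a lower number here means a stronger inhibitor, a higher number a weaker inhibitor:
compound 1 `C=CC(=C)CC[C@@H]1[C@@]2(C)CCC[C@](C)(COC(=O)/C=C/c3ccc(O)cc3)[C@@H]2CC[C@@]1(C)O` gives 19300 nM in this assay.
compound 3 `C=CC(=C)CC[C@@H]1[C@@]2(C)CCC[C@](C)(COC(=O)/C=C/c3ccc(O)c(OC)c3)[C@@H]2CC[C@@]1(C)O` gives 16900 nM in this assay.
compound 2 `C=C[C@@]1(C)O[C@H]1C[C@H]1C(=C)CC[C@@H]2[C@]1(C)CCC[C@]2(C)C(=O)O` gives > 40000 nM in this assay, which is a limit and not a number.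

Compound 2 therefore stands at the upper end of what this assay reports, together with the limit of > 40000 nM in this assay, at which 1 of the 3 values shown sits. Going by the values given here, of the three compounds, compound 1 and compound 3 give numbers, and the one measured step between them, a 1.1-fold lower number from compound 1 to compound 3 (0.06 log units; within the scatter), is within the scatter. Compound 2 has no measured neighbour that differs from it in one place, so nothing in the measured set places it relative to a change of its own kind.

Compound 4 `C=C[C@]1(C)O[C@H]1C[C@H]1C(=C)CC[C@@H]2[C@]1(C)CCC[C@]2(C)C(=O)O` is the next compound; against compound 2 the difference is the two compounds have the same atoms and bonds and differ only in configuration as drawn: 1 of 6 stereo elements differ; a stereocentre at a saturated ring carbon is drawn R in compound 2 and S in compound 4. Among the compounds with values here, no measured step concerns a change of configuration; the only measured step, a 1.1-fold lower number from compound 1 to compound 3 (0.06 log units; within the scatter), concerns a methoxy on an aromatic carbon of a different core and does not bear on this change. There is thus no basis for a direction beyond the scatter. Compound 4 is expected to stay near compound 2 in this assay, most likely again reported as a limit, so the expected step that the limit leaves unreadable from compound 2 to compound 4 is none beyond the scatter. For compound 4 the estimate is 45000 nM, with a range of 20000 nM to 100000 nM.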

Compound 4, half-maximal inhibitory concentration: > 40000 nM
Compound 4: only a limit was reported (the forecaster's own chance of this, stated with the estimate: 70%); the middle value does not contradict the limit.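

Compound 2 and compound 4 differ only in configuration as drawn, and in this assay neither gives a number, so no step can be read between them: the limit of > 40000 nM in this assay, at which 2 of the 4 values shown sit.

The compounds shown leave open whether the change of configuration at this saturated ring carbon shifts the half-maximal inhibitory concentration at all.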